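The source may hold more compounds than are shown below. What is called first, only, known or untested is meant among the compounds shown, and "the series" means these compounds.

Measured in a functional assay on KB cells (Homo sapiens) for inhibition (on this read-out lower numbers stand for stronger inhibition and higher numbers for weaker inhibition), for the series so far
- compound 1 `COC[C@H]1O[C@@H](n2c(Cl)nc3cc(Cl)c(Cl)cc32)[C@H](OC(C)=O)[C@@H]1OC(C)=O` gives 80000 nM
- compound 2 `CC(=O)OC1C(CBr)OC(n2c(Cl)nc3cc(Cl)c(Cl)cc32)C1OC(C)=O` gives 60000 nM
- compound 3 `CC(=O)OC1C(CI)OC(n2c(Cl)nc3cc(Cl)c(Cl)cc32)C1OC(C)=O` gives 60000 nM

Compound 3 at 60000 nM stands level with compound 2, and compound 1 lies within the scatter of both, so the three numbers do not separate from one another in this assay at this stage.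

The next structure is compound 4 `CSCC1OC(n2c(Cl)nc3cc(Cl)c(Cl)cc32)C(OC(C)=O)C1OC(C)=O` and its difference from compound 3 is methylsulfanyl in place of iodo on a saturated chain carbon bound to a saturated ring carbon in full, that is, methylsulfanyl in place of iodo on a saturated chain carbon bound to a saturated ring carbon.

Within the data shown here, one measured step bears on this place. It is no change at the digits printed from compound 2 to compound 3 (within the scatter) for iodo in place of bromo on the same kind of carbon, a step that stays within the scatter. Among the measured compounds shown here, no measured step has methylsulfanyl entering there, so the guidance is thin and the range is kept wide. For the measured compounds named here, with only that step as a guide, no change beyond the scatter is expected in this assay in either direction.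

The expected step is no change at the digits printed from compound 3 to compound 4 (within the scatter) and it is not expected to leave the scatter. For compound 4 the estimated value is 60000 nM with an expected range of 30000 nM to 100000 nM for repeated measurements.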

Compound 4, half-maximal inhibitory concentration: 70000 nM
For compound 4 the middle estimate is 1.2-fold (0.07 log units) below the measured one, within the range that was stated.
By their numbers in this assay, from the lowest: compounds 2, 3, 4 and 1 (each within the scatter of the next).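

In this assay, the place on a saturated chain carbon bound to a saturated ring carbon now has a change that goes beyond swapping one halogen for another: methylsulfanyl in place of iodo gives a 1.2-fold higher number from compound 3 to compound 4 (0.07 log units; within the scatter), and methylsulfanyl in place of bromo gives a 1.2-fold higher number from compound 2 to compound 4 (0.07 log units; within the scatter). Going from a single halogen atom to a group of two heavy atoms, carbon and sulfur, that counts one hydrogen-bond acceptor therefore does not move the read-out out of the scatter, so this place shows no sensitivity to the three groups compared so far. No independent data accompany these numbers that could account for this flat result.

Going by these compounds, whether an amine, a carboxylic acid or a longer chain at this place would separate from these values remains open. Also open is whether this place stays as flat with a free hydroxyl in place of the acetyl esters, since every compound shown carries those esters and the shared core.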